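Replacing the 2-chlorophenyl of compound 3

The compounds below may be only part of what the source reports. "The series", "measured", "known", "first", "only" and "open" are said of these compounds alone.

Measured in a functional assay on MGC-803 cells (Homo sapiens) for cytotoxicity, read by MTT assay, with a stated time of 48 h (on this read-out higher numbers stand for weaker inhibition and lower numbers for stronger inhibition), are these compounds:
compound 1 `CC1=NN(C(=O)c2ccc(C)cc2)C(c2ccccc2O)C1` gives 26300 nM
compound 2 `CCN(CC)CC(=O)N1N=C(C)CC1c1ccccc1O` gives 39800 nM
compound 3 `O=C(c1ccccc1Cl)N1N=C(c2cc3ccccc3oc2=O)CC1c1ccccc1` gives 6640 nM

Compound 3 has the lowest number of the three, and its gaps to compound 1 and compound 2 both lie beyond the scatter. Compound 4 `O=C(CNC1CC1)N1N=C(c2cc3ccccc3oc2=O)CC1c1ccccc1` differs from it in one place: (cyclopropylamino)methyl in place of 2-chlorophenyl on a carbonyl carbon. That is, (cyclopropylamino)methyl in place of 2-chlorophenyl on a carbonyl carbon. Among the compounds with values here, one measured step bears on this: a 1.5-fold higher number from compound 1 to compound 2 (0.18 log units; within the scatter). It makes a similar exchange on a different core and stays within the scatter. Within the data shown here, no step on the core of compound 3 has been measured, so only a small upward step is expected in this assay. The expected step is a 1.5-fold higher number from compound 3 to compound 4 (0.18 log units; within the scatter). Compound 4 is estimated at 10000 nM, with an expected range from 3000 nM to 32000 nM.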

Compound 4, half-maximal inhibitory concentration: "not active" (no number reported)
For compound 4 the study gives words and no number; no gap can be computed for the estimate.
By their numbers in this assay, from the lowest: compound 3; then compounds 1 and 2 (each within the scatter of the next).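

Within the data shown here, compound 4 is reported in words as "not active", without a number, so no step from compound 3 can be read. The compounds shown leave open how large that change is on the shared core. No evidence here bears on this result.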